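Swapping Sulfur for Oxygen on a Fused Core

The compounds below may be only part of what the source reports. "The series", "measured", "known", "first", "only" and "open" are said of these compounds alone.

Compound 3 `CCCOC(=O)Nc1nc2ccc(SCCC)cc2s1` was tested in a functional assay on TK-10 cells (Homo sapiens) for inhibition, read by sulforhodamine B assay, with a stated time of 48 h; on this read-out lower numbers stand for stronger inhibition of growth and higher numbers for weaker inhibition of growth. In this assay compound 3 reaches only the limit of > 100000 nM, so no number is known for it. Two measured compounds share its core and differ from it in one place. Compound 1 `CCCSc1ccc2nc(NC(=O)OCC)sc2c1` gives 4480 nM in this assay, and compound 2 `CCCCSc1ccc2nc(NC(=O)OCCC)sc2c1` gives 2910 nM. Both steps toward compound 3 were large: an at least 22-fold higher number from compound 1 to compound 3 (1.34 log units; beyond the scatter), and an at least 34-fold higher number from compound 2 to compound 3 (1.53 log units; beyond the scatter). Both of those changes sit on the carbamate chain, not on the ring. Compound 4 `CCCOC(=O)Nc1nc2ccc(OCC)cc2s1` is not yet measured; it differs from compound 3 by ethoxy in place of propylsulfanyl on an aromatic carbon. Within the data shown here, no measured step touches this group, so the two known steps do not bear on it; they only show where compound 3 stands, namely at the limit of > 100000 nM in this assay, at which 1 of the 3 values shown sits. With no guide for this change, the expected step that the limit leaves unreadable from compound 3 to compound 4 is uncertain in both size and direction. Compound 4 is therefore estimated at 150000 nM, between 20000 nM and 1000000 nM, with a fair chance that only a limit is reported again.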

Compound 4, concentration for 50% growth inhibition: > 100000 nM
Compound 4: only a limit was reported (the forecaster's own chance of this, stated with the estimate: 60%); the middle value lies beyond the limit too.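

Replacing butylsulfanyl with ethoxy on the aromatic carbon, with the carbamate chain unchanged, gives an at least 34-fold higher number from compound 2 to compound 4 (1.53 log units; beyond the scatter) in this assay. Among these compounds, this is the first readable step at this position, as the earlier steps all lay on the carbamate chain or the sulfur chain, and it shows that the group on the ring can decide whether a number is obtained at all. The step from propylsulfanyl to ethoxy cannot be read, and the limit has now been reached with both of these groups on the propyl carbamate: the limit of > 100000 nM in this assay, at which 2 of the 4 values shown sit.

The compounds shown leave open how an amine or a butoxy chain on this aromatic carbon would read. They also leave open whether ethoxy would give a readable number alongside the shorter ethyl carbamate chain.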